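This account rests on a few compounds, and the source may have more. Where it says the series, first, only, none or still open, it means among the compounds named here.

In a functional assay on MDA-MB-231 cells (Homo sapiens) for antiproliferative activity, read by MTT assay, with a stated time of 24 h (a higher number here means a weaker inhibitor, a lower number a stronger inhibitor), three compounds built on a shared core have been measured. Compound 1 `Cc1ccccc1NNC(=O)c1ccccc1NS(=O)(=O)c1cnc(O)nc1O` returns only a limit, > 20000 nM. Compound 2 `Cc1cccc(NNC(=O)c2ccccc2NS(=O)(=O)c2cnc(O)nc2O)c1` also returns only a limit, > 20000 nM. Among the compounds with values here, compound 3 `O=C(NNc1cccc(Cl)c1)c1ccccc1NS(=O)(=O)c1cnc(O)nc1O` gives 11800 nM, the only actual number among the three, and so the only firm reference point in the set.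

Compound 4 `O=C(NNc1ccc(F)cc1)c1ccccc1NS(=O)(=O)c1cnc(O)nc1O` keeps the core and carries 4-fluorophenyl in place of 3-chlorophenyl on an amine nitrogen. The measured steps that bear on this change are those that alter the aryl group on the same nitrogen. They show an at least 1.6-fold lower number from compound 1 to compound 3 (0.22 log units; that floor lies within the scatter) and an at least 1.6-fold lower number from compound 2 to compound 3 (0.22 log units; that floor lies within the scatter). Both are floors only, and neither shows a change beyond the scatter. The step that the two limits leave unreadable from compound 1 to compound 2 adds nothing further. Within the data shown here, no measured compound carries fluorine or a 4-substituted phenyl, so the direction of the step rests on thin ground.

Compound 3 stands at 11800 nM. Compound 1 and compound 2 read only as limits. On this basis, a slightly higher number seems more likely than a lower one, but nothing beyond the scatter is expected. The expected change is a 1.4-fold higher number from compound 3 to compound 4 (0.13 log units; within the scatter). A reading that gives only a limit would also be no surprise, given (the limit of > 20000 nM in this assay, at which 2 of the 3 values shown sit). The estimated value for compound 4 is 16000 nM, with an expected range from 7000 nM to 30000 nM.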

Compound 4, half-maximal inhibitory concentration: > 20000 nM
Compound 4 gave a limit, no number; the forecaster's own chance of this, stated with the estimate: 45%; middle value at least 1.2-fold (0.09 log units) from the limit.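

In this assay compound 4 returns only a limit, > 20000 nM, so 4-fluorophenyl on this amine nitrogen yields no number. Against the one measured aryl group, the result reads as an at least 1.6-fold higher number from compound 3 to compound 4 (0.22 log units; that floor lies within the scatter), which means that this first fluorine-bearing compound gives no firm evidence of a change beyond the scatter, although the true size of the step may be larger than this floor. Within the data shown here, the steps from compound 1 and from compound 2 to compound 4 join two limits and cannot be read, which leaves compound 3 as the only compound in the set with a number, and the limit now covers most of the series: the limit of > 20000 nM in this assay, at which 3 of the 4 values shown sit.

The change from compound 3 to compound 4 swaps the halogen and alters its place on the phenyl ring in a single step, so the two cannot be told apart here. Going by these compounds, it also remains open whether a methoxy group, a nitrile or a phenyl ring with no substituent at all on this amine nitrogen would give a number, and how that number would compare with compound 3.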